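The source may report more compounds than this note shows. Statements on the series, on what has been measured and on what is new or still open speak of the compounds shown alone.

Measured compounds in a functional assay on A549 cells (Homo sapiens) for cytotoxicity, read by CCK-8 assay, with a stated time of 72 h; on this read-out lower numbers stand for stronger inhibition and higher numbers for weaker inhibition:
compound 1 `COc1ccccc1/C=c1/[nH]c(=O)/c(=C\c2cccc(Cl)c2Cl)[nH]c1=O`: "not active" (no number reported)
compound 2 `C=CCn1c(=O)/c(=C\c2cc(Br)ccc2F)[nH]c(=O)/c1=C\c1ccccc1OC`: "not active" (no number reported)
compound 3 `COc1ccccc1/C=c1/[nH]c(=O)/c(=C\c2nc[nH]c2C(C)(C)C)[nH]c1=O`: 90 nM

Compound 2 stands without a single number in this assay; it shares that position with compound 1, which also gave no number. Among the compounds with values here, compound 3 is the only member of the series with a reported half-maximal inhibitory concentration, and it carries a different second ring from the other two, so no one-place comparison links it to compound 2.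

Compound 4 `C=CCn1c(=O)/c(=C\c2ccccc2F)[nH]c(=O)/c1=C\c1ccccc1OC` is the next entry. It differs from compound 2 in one place: hydrogen in place of bromo on an aromatic carbon. Within the data shown here, no pair of measured compounds shows what this change does in this assay, so no step of a size beyond the usual scatter is expected, and no direction can be assigned from the data, since compound 2 itself has no number to move from.

Compound 4 is expected, like compound 2, most likely to return no number in this assay; if a number is obtained, the estimate for compound 4 is 30000 nM, with a range from 5000 nM to 150000 nM.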

Compound 4, half-maximal inhibitory concentration: "not active" (no number reported)
For compound 4 the study gives words and no number; no gap can be computed for the estimate.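

Compound 2 and compound 4 both return no number in this assay, so no step can be read between them, and no measurement shown bears on this result. Left open is what the change from 5-bromo-2-fluorophenyl to 2-fluorophenyl does where a number can be obtained.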